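Triazole series: aryl swap on the ring nitrogen

A few compounds are considered here, and "the series" means these few. Any claim that something is new, unique, unknown or untested is made for them only; others in the source may bear on it.

Of the compounds shown here, three of the shared core have been measured. Compound 1 `Cc1ccc(-n2nc(-c3ccc(C(F)(F)F)cc3O)nc2-c2ccccc2O)cc1` gives 71.5% in a functional assay on PC-12 cells (Rattus norvegicus) for cytotoxicity, read by MTT assay, with stated times of 2 h and 24 h, tested at 1 uM; on this read-out higher numbers stand for a stronger effect at the one concentration tested and lower numbers for a weaker effect. Compound 2 `Oc1cc(C(F)(F)F)ccc1-c1nc(-c2ccccc2O)n(-c2ccc(Cl)cc2)n1` gives 68% in this assay, and compound 3 `Oc1cc(C(F)(F)F)ccc1-c1nc(-c2ccccc2O)n(-c2ccc(C(F)(F)F)cc2)n1` gives 70.7% in this assay. Compound 3 stands second highest of the three numbers, with compound 1 nearest and compound 2 furthest, and every gap among them sits within the scatter. The three single-point steps, a number 3.5 percentage points lower from compound 1 to compound 2 (within the scatter), a number 0.8 percentage points lower from compound 1 to compound 3 (within the scatter) and a number 2.7 percentage points higher from compound 2 to compound 3 (within the scatter), each exchange one group on an aromatic carbon of the aryl carried by the ring nitrogen and each stays within the scatter.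

Compound 4 `COc1cccc(-n2nc(-c3ccc(C(F)(F)F)cc3O)nc2-c2ccccc2O)c1` is not yet measured. It differs from compound 3 by 3-methoxyphenyl in place of 4-(trifluoromethyl)phenyl on an aromatic nitrogen. Going by the values given here, no measured step introduces a methoxy group or moves the substituent on that aryl, so the bearing of the earlier steps is indirect; they show only that exchanges on this aryl have left the read-out unchanged in this assay. The expected step is therefore none beyond the scatter, estimated as a number 1.7 percentage points lower from compound 3 to compound 4 (within the scatter). For compound 4 the estimate in this assay is 69%, with a range from 55% to 80%.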

Compound 4, a percentage reported as activity, at one concentration (the size of the read-out at that concentration, not a potency): 68.3%
Compound 4: middle estimate off by 0.7 percentage points, on the high side, and the stated range covers the measured number.
By their numbers in this assay, from the lowest: compounds 2, 4, 3 and 1 (each within the scatter of the next).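

Replacing the aryl on the ring nitrogen with 3-methoxyphenyl adds a methoxy group and a hydrogen-bond acceptor, neither of which the earlier aryls carry, yet in this assay the read-out shows a number 2.4 percentage points lower from compound 3 to compound 4 (within the scatter), a number 0.3 percentage points higher from compound 2 to compound 4 (within the scatter) and a number 3.2 percentage points lower from compound 1 to compound 4 (within the scatter). Across these four compounds, the read-out therefore does not separate 3-methoxyphenyl from 4-methylphenyl, 4-chlorophenyl or 4-(trifluoromethyl)phenyl at this position. Nothing available accounts for this flat result.

The compounds shown leave open whether an amine, a carboxylic acid or a longer chain on this aryl would move the read-out beyond the scatter. They also leave open whether 4-methoxyphenyl would read like 3-methoxyphenyl, and the single concentration gives no measure of potency for any of them.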